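The source may report more compounds than this note shows. Statements on the series, on what has been measured and on what is new or still open speak of the compounds shown alone.

Among the measured compounds shown here, the three compounds measured so far share one core and differ in the chain attached to it and in the group on the core. In a functional assay on the whole organism with Rattus norvegicus as the target, at a dose of 100 mg/kg (on this read-out higher numbers stand for more inhibition at the one dose given (going by the name of the read-out) and lower numbers for less inhibition), compound 1 `C/N=C(\S)NCCCCn1nc(C)ccc1=O` gives 44.5%. Compound 2 `C/N=C(\S)NCCCCCn1nc(-c2ccccc2)ccc1=O` gives 68.9% in this assay. Compound 3 `C/N=C(\S)NCCCCCCn1nc(C)ccc1=O` gives -12.5% in this assay, the lowest of the three numbers: its nearest neighbour is compound 1, whose number lies higher by a margin beyond the usual scatter, and compound 2 lies higher still, also beyond the scatter.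

Compound 4 `C/N=C(\S)NCCCCCn1nc(C)ccc1=O` has not yet been measured in this assay. Against compound 3 it carries a group of 5 heavy atoms (2 carbon, 2 nitrogen, 1 sulfur; no ring) in place of a group of 6 heavy atoms (3 carbon, 2 nitrogen, 1 sulfur; no ring), on a saturated chain carbon, five bonds along the chain from an aromatic nitrogen. For the measured compounds named here, no measured pair differs in exactly this way, so the size of that step cannot be read off directly. Compound 4 shares its core with compound 1 and compound 3 and differs from both only in the chain, and the numbers of those two lie far apart. On that basis the step from compound 3 to compound 4 is expected to be upward and beyond the scatter, with compound 4 expected to come in between the readings of compound 1 and compound 3, at a number 42.5 percentage points higher from compound 3 to compound 4 (beyond the scatter). Compound 4 is estimated at 30% in this assay, within a range from -5% to 60%.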

Compound 4, a percentage reported as inhibition, in the whole organism at one dose (the size of the read-out at that dose, not a potency): 3.2%
The estimate for compound 4 lay 26.8 percentage points above the measured number, and the stated range covers the measured number.
By their numbers in this assay, from the lowest: compound 3; then compound 4; then compound 1; then compound 2.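

In this assay, the chain can now be read in single steps among the methyl compounds: the change to a group of 6 heavy atoms, four bonds along the chain from an aromatic nitrogen, gives a number 41.3 percentage points lower from compound 1 to compound 4 (beyond the scatter), while the change to a group of 5 heavy atoms, five bonds along the chain from an aromatic nitrogen, gives a number 15.7 percentage points higher from compound 3 to compound 4 (beyond the scatter). Among these three methyl compounds the number therefore falls as the chain lengthens, with the large step at the shorter end and the modest one at the longer end, and compound 2 stands outside this comparison as it carries phenyl. The group on the aromatic carbon can also be read directly for the first time, as methyl in place of phenyl gives a number 65.7 percentage points lower from compound 2 to compound 4 (beyond the scatter), and nothing shown offers a reason for either effect.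

The compounds shown leave open whether phenyl keeps its advantage on the shorter or longer chains, since it appears on one chain only. They also leave open how an ethyl group or a methoxy group on that aromatic carbon, or an oxygen atom in place of the sulfur, would read in this assay.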